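Swapping 2-methylphenyl for 4-bromophenyl on the amide

The compounds below may be only part of what the source reports. "The series", "measured", "known", "first", "only" and "open" are said of these compounds alone.

Measured in a functional assay on HT-29 cells (Homo sapiens) for cytotoxicity, read by MTT assay, with a stated time of 72 h; on this read-out lower numbers stand for stronger inhibition and higher numbers for weaker inhibition:
- compound 1 `O=C(CN1CCN(c2nnc(Cc3ccccc3)c3ccccc23)CC1)Nc1ccc(F)c(C(F)(F)F)c1`: 4590 nM
- compound 2 `O=C(CN1CCN(c2nnc(Cc3ccccc3)c3ccccc23)CC1)Nc1ccc(F)c(F)c1`: 9510 nM
- compound 3 `Cc1ccccc1NC(=O)CN1CCN(c2nnc(Cc3ccccc3)c3ccccc23)CC1`: 113000 nM

Compound 3 has the highest number of the three, which means the weakest inhibition. Compound 4 `O=C(CN1CCN(c2nnc(Cc3ccccc3)c3ccccc23)CC1)Nc1ccc(Br)cc1` carries 4-bromophenyl in place of 2-methylphenyl on an amide-type nitrogen. Within the data shown here, no bromine compound has been measured, so the nearest guide is the two halogen-bearing rings. Moving to 2-methylphenyl gave large steps, a 25-fold higher number from compound 1 to compound 3 (1.39 log units; beyond the scatter) and a 12-fold higher number from compound 2 to compound 3 (1.07 log units; beyond the scatter). Changing between those two rings gave only a modest one, a 2.1-fold higher number from compound 1 to compound 2 (0.32 log units; beyond the scatter). The reverse kind of change is therefore expected to give a large step down in this assay, estimated as a 9.4-fold lower number from compound 3 to compound 4 (0.97 log units; beyond the scatter). Compound 4 is expected at 12000 nM, within an estimated range of 3500 nM to 40000 nM.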

Compound 4, half-maximal inhibitory concentration: 60200 nM
Compound 4: the middle estimate sits 5.0-fold (0.70 log units) below what was measured; measured number above the stated range.
By their numbers in this assay, from the lowest: compound 1; then compound 2; then compounds 4 and 3 (each within the scatter of the next).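

In this assay, a halogen on the ring does not by itself bring a low number: compound 4 goes against that idea, since 4-bromophenyl and 2-methylphenyl on the amide-type nitrogen read alike, with a 1.9-fold lower number from compound 3 to compound 4 (0.27 log units; within the scatter). The fluorine-bearing rings stay clearly apart from 4-bromophenyl, with a 6.3-fold higher number from compound 2 to compound 4 (0.80 log units; beyond the scatter) and a 13-fold higher number from compound 1 to compound 4 (1.12 log units; beyond the scatter). Nothing available here explains this difference between the rings. Still open, as far as these compounds go, is how a ring carrying an amine or a carboxylic acid would read at this position, and whether the bromine itself or its place on the ring sets the number for compound 4.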